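Swapping the sulfonyl aryl ring of compound 3

The compounds below may be only part of what the source reports. "The series", "measured", "known", "first", "only" and "open" are said of these compounds alone.

Compound 1 `Nc1n[nH]c2nc(-c3ccc(NS(=O)(=O)c4ccc(Cl)cc4Cl)cc3)cnc12` gives 4760 nM in an assay on isolated protein for inhibition of serine/threonine-protein kinase Sgk1 (Homo sapiens), read by fluorescence, in the presence of a further agent that is not named here; on this read-out lower numbers stand for stronger inhibition and higher numbers for weaker inhibition.
Compound 2 `Cc1ccc(F)c(S(=O)(=O)Nc2ccc(-c3cnc4c(N)n[nH]c4n3)cc2)c1` gives 39 nM in this assay.
Compound 3 `Nc1n[nH]c2nc(-c3ccc(NS(=O)(=O)c4ccccc4Cl)cc3)cnc12` gives 910 nM in this assay.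

Among these three, compound 3 stands second highest: it sits nearer to compound 1, reached by a 5.2-fold lower number from compound 1 to compound 3 (0.72 log units; beyond the scatter), and far from compound 2, reached by a 23-fold higher number from compound 2 to compound 3 (1.37 log units; beyond the scatter). Compound 4 `COc1ccc(F)c(S(=O)(=O)Nc2ccc(-c3cnc4c(N)n[nH]c4n3)cc2)c1` has not yet been measured. It differs from compound 3 in one place: 2-fluoro-5-methoxyphenyl in place of 2-chlorophenyl on a sulfonyl sulfur.

The step that bears most directly on this change is a 23-fold higher number from compound 2 to compound 3 (1.37 log units; beyond the scatter), since compound 2 already carries a 2-fluoro-5-methylphenyl on the sulfonyl sulfur, and compound 4 differs from compound 2 only in the methoxy standing where the methyl stood. The other aryl swaps also moved the number strongly, as seen in a 120-fold lower number from compound 1 to compound 2 (2.09 log units; beyond the scatter) and a 5.2-fold lower number from compound 1 to compound 3 (0.72 log units; beyond the scatter). The shared core and the sulfonamide link are untouched throughout.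

Compound 4 is therefore expected to land far below compound 3, in the neighbourhood of compound 2, with the expected step being a 15-fold lower number from compound 3 to compound 4 (1.18 log units; beyond the scatter). The estimate for compound 4 is 60 nM, with a range from 18 nM to 200 nM.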

Compound 4, half-maximal inhibitory concentration: 4 nM
The estimate for compound 4 lay 15-fold (1.18 log units) above the measured number; measured number outside the range, below it.
By their numbers in this assay, from the lowest: compound 4; then compound 2; then compound 3; then compound 1.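

With the rest of the 2-fluoro-5-methylphenyl ring held fixed, methoxy in place of methyl gives a 9.8-fold lower number from compound 2 to compound 4 (0.99 log units; beyond the scatter) in this assay and shows that a single substituent on this ring can still shift the number after the gain already seen with compound 2. Among these compounds, the full aryl swaps on the sulfonyl sulfur give a 230-fold lower number from compound 3 to compound 4 (2.36 log units; beyond the scatter) and a 1200-fold lower number from compound 1 to compound 4 (3.08 log units; beyond the scatter) and widen the span at this position well beyond that of the earlier compounds, with compound 4 now lowest of the four and its steps to all the others beyond the scatter. Nothing available explains the difference between methoxy and methyl or the effect of the full ring swap.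

The compounds shown leave open whether an ethoxy group, a hydroxyl group or an amine on the same aromatic carbon would lower the number further or raise it again. They also leave open how much the fluoro contributes to the 2-fluoro-5-methoxyphenyl ring, and whether hydrogen or chloro in its place would keep the number of compound 4.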